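The source may hold more compounds than are shown below. What is called first, only, known or untested is meant among the compounds shown, and "the series" means these compounds.

Measured compounds in a functional assay on MCF7 cells (Homo sapiens) for antiproliferative activity, read by MTT assay, with a stated time of 72 h; on this read-out lower numbers stand for stronger inhibition and higher numbers for weaker inhibition:
compound 1 `CCN(CC)CCCOc1cc2ncnc(Nc3ccc(C#N)cc3)c2cc1OC` gives > 100000 nM;
compound 2 `COc1cc2c(Nc3ccc(C#N)cc3)ncnc2cc1OCCCN1CCc2ccccc2C1` gives > 100000 nM.

Compound 1 stands only at a limit of this assay, not at a number: in this assay compound 1 gives > 100000 nM, a limit. Compound 2 likewise reaches only a limit in this assay, > 100000 nM. Both values sit at the limit of > 100000 nM in this assay, at which 2 of the 2 values shown sit, so the step that the two limits leave unreadable from compound 1 to compound 2 cannot be read in size or direction.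

Compound 3 `COc1cc2c(Nc3ccc(C#N)cc3)ncnc2cc1OCCCN1CCC(N2CCCCC2)CC1` differs from compound 1 by 4-(piperidin-1-yl)piperidin-1-yl in place of diethylamino on a saturated chain carbon, three bonds along the chain from an oxygen on an aromatic ring. Going by the values given here, the one measured step that bears on this change, from compound 1 to compound 2, also replaces diethylamino with a cyclic amine and is unreadable because of the limit of > 100000 nM in this assay, at which 2 of the 2 values shown sit. No readable step therefore points to any shift in this assay, in either direction, beyond the scatter. The step of a number no higher from compound 1 to compound 3 (the limit leaves the size open) is expected to be small. Compound 3 is estimated to give 100000 nM, with a range from 30000 nM to 300000 nM, and most likely only a limit again.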

Compound 3, half-maximal inhibitory concentration: 19600 nM
Estimate against measurement, compound 3: 5.1-fold (0.71 log units) above, and the stated range ends above it.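

In this assay, the place on a saturated chain carbon, three bonds along the chain from an oxygen on an aromatic ring, now yields its first readable steps. With 4-(piperidin-1-yl)piperidin-1-yl in place of diethylamino there is an at least 5.1-fold lower number from compound 1 to compound 3 (0.70 log units; beyond the scatter), and with the same group in place of 1,2,3,4-tetrahydroisoquinolin-2-yl there is an at least 5.1-fold lower number from compound 2 to compound 3 (0.70 log units; beyond the scatter), so the amine at this place can change the read-out, while the step between the two earlier compounds still cannot be read. Both new steps give only a lower bound on their size, and the true distance stays open: the limit of > 100000 nM in this assay, at which 2 of the 3 values shown sit.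

The compounds shown do not separate the contribution of the second nitrogen from that of the two rings. A single piperidin-1-yl or a 4-(dimethylamino)piperidin-1-yl at the same place would bear on that question.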